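From hydroxy to cyano on the core of compound 3

A few compounds are considered here, and "the series" means these few. Any claim that something is new, unique, unknown or untested is made for them only; others in the source may bear on it.

Measured so far in a functional assay on HCT-116 cells (Homo sapiens) for cytotoxicity, with a stated time of 48 h (a higher number here means a weaker inhibitor, a lower number a stronger inhibitor), are three values:

Compound 1 `N#Cc1ccc(-c2cncc(-c3cc4ccc(O)cc4[nH]3)c2)cc1` gives 6000 nM here
Compound 2 `CS(=O)(=O)c1ccc(-c2cncc(-c3cc4ccc(O)cc4[nH]3)c2)cc1` gives 2000 nM here
Compound 3 `Oc1ccc(-c2cncc(-c3cc4ccc(O)cc4[nH]3)n2)cc1` gives 3000 nM here

Compound 3 lies within the usual scatter of both compound 1 and compound 2, so it cannot be ranked against either. Compound 4 `N#Cc1ccc(-c2cncc(-c3cc4ccc(O)cc4[nH]3)n2)cc1` differs from compound 3 in one place, with cyano in place of hydroxy on an aromatic carbon. Among the compounds with values here, no measured step makes this exact swap. Within the data shown here, the only measured step, a 3.0-fold lower number from compound 1 to compound 2 (0.48 log units; beyond the scatter) as a modest change, replaces cyano with methylsulfonyl and so bears on it only indirectly. Compound 1 also carries the cyano group, on a closely similar core, and its 6000 nM lies within the scatter of compound 3. The number in this assay is therefore expected to move little, perhaps slightly upward. The expected step is a 1.3-fold higher number from compound 3 to compound 4 (0.12 log units; within the scatter) and that stays within the scatter. For compound 4 the estimated value is 4000 nM with an expected range of 1500 nM to 10000 nM around it.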

Compound 4, half-maximal inhibitory concentration: 13000 nM
The estimate for compound 4 lay 3.3-fold (0.51 log units) below the measured number; measured number outside the range, above it.
By their numbers in this assay, from the lowest: compounds 2, 3 and 1 (each within the scatter of the next, the first and the last beyond it); then compound 4.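

On this core, the group on the aromatic carbon para to a large group does affect the result in this assay: going from 4-hydroxyphenyl to 4-cyanophenyl gives a 4.3-fold higher number from compound 3 to compound 4 (0.64 log units; beyond the scatter), so the inhibitor becomes weaker. This is the first step shown at this position that clearly exceeds the scatter on this core. The swap removes a hydrogen-bond donor and keeps a hydrogen-bond acceptor, but that count alone does not establish what drives the change, and no measurement here accounts for the step.

On these data alone, it remains open whether the donor itself matters, or whether the hydroxy group is favoured for another reason. A methoxy group or an amine at this position would help to separate these possibilities, as would methylsulfonyl on this same core.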